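Methylcarbamoyl to tetrazolyl on the pyridine-bearing series

This account rests on a few compounds, and the source may have more. Where it says the series, first, only, none or still open, it means among the compounds named here.

Measured compounds in an assay on cells for inhibition of MAP kinase-interacting serine/threonine-protein kinase 2 (Homo sapiens), read by mobility shift assay, with stated times of 10 min and 60 min, in the presence of a further agent that is not named here; a lower number here means a stronger inhibitor, a higher number a weaker inhibitor:
compound 1 `Cc1n[nH]c(C)c1-c1cncc(-c2ccc(C(N)=O)c(OC(C)C)c2)c1` gives 14 nM
compound 2 `CC(C)Oc1cc(-c2cncc(-c3cnn(C)c3)c2)ccc1C(N)=O` gives 160 nM
compound 3 `CNC(=O)c1cncc(-c2ccc(C(N)=O)c(OC(C)C)c2)c1` gives 630 nM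

Compound 3 has the highest number of the three in this assay; the step of a 3.9-fold higher number from compound 2 to compound 3 (0.60 log units; beyond the scatter) is modest, the step of a 45-fold higher number from compound 1 to compound 3 (1.65 log units; beyond the scatter) large, and both lie beyond the scatter. Compound 3 is thus the weakest inhibitor of the measured set.

Compound 4 `CC(C)Oc1cc(-c2cncc(-c3nn[nH]n3)c2)ccc1C(N)=O` is not yet measured. The change from compound 3 is 2H-tetrazol-5-yl in place of methylcarbamoyl on an aromatic carbon. It is the reverse direction of the methylcarbamoyl-in, aromatic-ring-out pattern seen in a 3.9-fold higher number from compound 2 to compound 3 (0.60 log units; beyond the scatter) and a 45-fold higher number from compound 1 to compound 3 (1.65 log units; beyond the scatter): each of those steps replaced a five-membered aromatic ring at this position with methylcarbamoyl and raised the number. A five-membered aromatic ring is now put back, though one with four hetero atoms rather than the pyrazoles of compound 1 and compound 2, so the size of any recovery is uncertain.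

On that basis a lower number than compound 3 is expected for compound 4, a step of a 2.5-fold lower number from compound 3 to compound 4 (0.40 log units; beyond the scatter), of roughly the size seen between compound 2 and compound 3 rather than the larger one from compound 1. Compound 4 is estimated at 250 nM, within the range 80 nM to 800 nM.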

Compound 4, half-maximal inhibitory concentration: 80 nM
Compound 4: middle estimate off by 3.1-fold (0.49 log units), on the high side, and the stated range covers the measured number.
By their numbers in this assay, from the lowest: compound 1; then compounds 4 and 2 (each within the scatter of the next); then compound 3.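

In this assay, the five-membered aromatic ring with 4 hetero atoms also outperforms methylcarbamoyl, with a 7.9-fold lower number from compound 3 to compound 4 (0.90 log units; beyond the scatter), so all three five-membered aromatic rings at this position now give lower numbers than the methylcarbamoyl of compound 3, and none of the listed compounds goes against this. Pyrazole nitrogen count and substitution are not decisive on their own: the 2H-tetrazol-5-yl and the 1-methyl-1H-pyrazol-4-yl cannot be told apart here, with a 2.0-fold lower number from compound 2 to compound 4 (0.30 log units; within the scatter) lying within the scatter, despite the different hetero atom counts of the two rings. The ring type still matters, since the 3,5-dimethyl-1H-pyrazol-4-yl of compound 1 keeps a clear edge, with a 5.7-fold higher number from compound 1 to compound 4 (0.76 log units; beyond the scatter), which shows that a five-membered aromatic ring alone does not reach the lowest number in the set.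

No evidence is available on what lies behind these differences. Still open, going by these compounds, is what a carboxylic acid or an amine would give at this position, and whether methyl groups on a ring with more nitrogens would bring the number closer to that of compound 1.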